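The source may report more compounds than this note shows. Statements on the series, on what has been measured and on what is new or still open speak of the compounds shown alone.

In a functional assay on HL-60 cells (Homo sapiens) for inhibition, read by MTT assay, with a stated time of 72 h (a higher number here means a weaker inhibitor, a lower number a stronger inhibitor), compound 1 `Cc1nc(-c2ccccc2)c(C(=O)N2CCN(c3cccc(Cl)c3)CC2)o1` gives 39.2 nM and compound 2 `Cc1nc(-c2ccccc2)c(C(=O)N2CCN(c3cccc(C#N)c3)CC2)o1` gives 39.6 nM, so compound 2 stands level with compound 1 within the scatter. Compound 3 `Cc1nc(-c2ccccc2)c(C(=O)N2CCN(c3ccc(C)c(C)c3)CC2)o1` shares the core of compound 2 and differs in one place: 3,4-dimethylphenyl in place of 3-cyanophenyl on an amine nitrogen in a ring. Going by the values given here, only one measured step bears on this change, a 1.0-fold higher number from compound 1 to compound 2 (0.00 log units; within the scatter), where cyano replaces chloro on an aromatic carbon. Among the compounds with values here, that step is a single exchange on the same aromatic ring, and no measured compound carries 3,4-dimethylphenyl, so the direction remains open and no step beyond the scatter is expected in this assay. The expected value for compound 3 is 40 nM, with an estimated range of 15 nM to 110 nM. The estimated step is a 1.0-fold higher number from compound 2 to compound 3 (0.00 log units; within the scatter).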

Compound 3, half-maximal inhibitory concentration: 43 nM
Compound 3: middle estimate off by 1.1-fold (0.03 log units), on the low side, within the range that was stated.
By their numbers in this assay, from the lowest: compounds 1, 2 and 3 (each within the scatter of the next).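

In this assay, replacing the 3-cyanophenyl on the amine nitrogen in the ring with 3,4-dimethylphenyl gives (a 1.1-fold higher number from compound 2 to compound 3 (0.04 log units; within the scatter)), and replacing the 3-chlorophenyl with the same group gives (a 1.1-fold higher number from compound 1 to compound 3 (0.04 log units; within the scatter)). Across these three compounds, the value therefore stays level with neither the nitrile nor the chloro group present, and a phenyl ring carrying two methyl groups in their place serves equally well at this position. No measurement at hand explains this level outcome.

Going by these compounds, all three compounds keep a substituted phenyl ring on that nitrogen, so it remains open whether a carboxylic acid or an amine on the ring would also stand level. On these data alone, it is equally open whether a methoxy group would do so, or whether this level outcome would hold in any other assay.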